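A chain-for-chain swap on the core of compound 3

A few compounds are considered here, and "the series" means these few. Any claim that something is new, unique, unknown or untested is made for them only; others in the source may bear on it.

Compound 1, `CC(C)c1noc(N2CCC(Oc3cc(N4CCc5cc(N6CCCCC6=O)ccc54)ncn3)CC2)n1`, gives 17 nM in an assay on CHO cells for agonist activity at Glucose-dependent insulinotropic receptor (Homo sapiens), read by a luciferase reporter and cAMP accumulation, with a stated time of 2 h; on this read-out lower numbers stand for an effect already at smaller amounts and higher numbers for an effect only at larger amounts of compound.
Compound 2, `CC(C)c1noc(N2CCC(Oc3cc(N4CCc5cc(N6CCCNS6(=O)=O)ccc54)ncn3)CC2)n1`, gives 24 nM.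
Compound 3, `CC(C)c1noc(N2CCC(Oc3cc(N4CCc5cc([S+]([O-])CCO)ccc54)ncn3)CC2)n1`, gives 48 nM.

Of the three numbers, that of compound 3 is the highest; the step of a 2.8-fold higher number from compound 1 to compound 3 (0.45 log units; beyond the scatter) lies beyond the scatter, whereas a 2.0-fold higher number from compound 2 to compound 3 (0.30 log units; within the scatter) stays within it. Compound 4, `CC(=O)N(C)c1ccc2c(c1)CCN2c1cc(OC2CCN(c3nc(C(C)C)no3)CC2)ncn1`, differs from compound 3 by a group of 5 heavy atoms (3 carbon, 1 nitrogen, 1 oxygen; no ring) in place of a group of 5 heavy atoms (2 carbon, 2 oxygen, 1 sulfur; no ring), on an aromatic carbon. Within the data shown here, the steps that bear on this are a 2.8-fold higher number from compound 1 to compound 3 (0.45 log units; beyond the scatter) and a 2.0-fold higher number from compound 2 to compound 3 (0.30 log units; within the scatter), each a ring giving way to the chain now leaving, and both small to modest. The present change trades one chain for another, so in this assay only a small step is expected, if any, more likely toward a lower number. Compound 4 is therefore estimated at 30 nM, within 12 nM to 80 nM, an expected step of a 1.6-fold lower number from compound 3 to compound 4 (0.20 log units; within the scatter).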

Compound 4, half-maximal effective concentration: 75 nM
Estimate against measurement, compound 4: 2.5-fold (0.40 log units) below, and the stated range covers the measured number.
By their numbers in this assay, from the lowest: compounds 1, 2, 3 and 4 (each within the scatter of the next, the first and the last beyond it).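

In this assay, swapping one open chain for another at this aromatic carbon gives no readable change (a 1.6-fold higher number from compound 3 to compound 4 (0.19 log units; within the scatter)), even though acetyl(methyl)amino has no hydrogen-bond donor. Yet this chain is separated from both ring-bearing compounds (a 3.1-fold higher number from compound 2 to compound 4 (0.49 log units; beyond the scatter); a 4.4-fold higher number from compound 1 to compound 4 (0.64 log units; beyond the scatter)), whereas the chain in compound 3 was clearly separated only from compound 1. No measurement shown explains these steps.

Going by these compounds, it remains open whether a longer chain such as acetyl(propyl)amino, or a carboxylic acid, would keep the number near those of the chains or bring it down toward those of the rings.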